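Swapping the aryl group on the aniline nitrogen of compound 3

The compounds below may be only part of what the source reports. "The series", "measured", "known", "first", "only" and "open" are said of these compounds alone.

Three compounds share a core in which an aniline nitrogen links a sulfonyl-bearing phenyl ring to the rest of the molecule. Compound 1 `Cc1noc(C2CCN(c3ncnc(Nc4ccc(S(C)(=O)=O)cc4)c3[N+](=O)[O-])CC2)n1` gives 260 nM in a functional assay for agonist activity at Glucose-dependent insulinotropic receptor (Homo sapiens) (a lower number here means that less compound is needed, a higher number that more compound is needed for the effect), compound 2 `CCc1noc(C2CCN(c3ncnc(Nc4ccc(S(C)(=O)=O)cc4)c3[N+](=O)[O-])CC2)n1` gives 10 nM, and compound 3 `CCS(=O)(=O)c1ccc(Nc2ncnc(N3CCC(c4nc(C(C)C)no4)CC3)c2[N+](=O)[O-])cc1` gives 17 nM. Among the compounds with values here, the single measured step, a 26-fold lower number from compound 1 to compound 2 (1.41 log units; beyond the scatter), concerns the chain on the oxadiazole, not the aryl group. Compound 3 stands second highest of the three numbers, with compound 2 nearest and compound 1 furthest.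

Compound 4 `CC(C)c1noc(C2CCN(c3ncnc(Nc4ccc(S(C)(=O)=O)c(F)c4)c3[N+](=O)[O-])CC2)n1` differs from compound 3 in one place: 3-fluoro-4-(methylsulfonyl)phenyl in place of 4-(ethylsulfonyl)phenyl on a nitrogen on an aromatic ring. Within the data shown here, no measured step bears on this change, since the only step concerns a different part of the molecule, and compounds 1 and 2 carry the methylsulfonyl group without the fluorine. For compound 4 no step beyond the scatter is therefore expected, and the estimated value is 15 nM, with a range from 5 nM to 50 nM, meaning a 1.1-fold lower number from compound 3 to compound 4 (0.05 log units; within the scatter).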

Compound 4, half-maximal effective concentration: 3.4 nM
Estimate against measurement, compound 4: 4.4-fold (0.64 log units) above; measured number outside the range, below it.
By their numbers in this assay, from the lowest: compound 4; then compounds 2 and 3 (each within the scatter of the next); then compound 1.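

The aryl group on the aniline nitrogen now proves to be a second place where the number in this assay responds, alongside the chain on the oxadiazole: this swap gives a 5.0-fold lower number from compound 3 to compound 4 (0.70 log units; beyond the scatter). The swap makes two changes at once, since a fluorine enters the ring while the ethyl on the sulfonyl gives way to methyl, so the step belongs to the pair of changes and cannot be divided between them. Nothing available here explains the step.

Still open, as far as these compounds go, is which of the two changes carries the step, a question that a partner of compound 4 with 4-(methylsulfonyl)phenyl and no fluorine could answer. Also open, from the compounds shown here alone, is how the number would respond to chlorine or a nitrile in place of the fluorine, or to a propyl chain on the sulfonyl.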